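From Methyl to Phenyl in an Aromatase Inhibitor Series

A few compounds are considered here, and "the series" means these few. Any claim that something is new, unique, unknown or untested is made for them only; others in the source may bear on it.

The measured compounds, with their results in an assay on isolated protein for inhibition of Aromatase (Homo sapiens), read by fluorescence and colorimetric assay, with a stated time of 30 min; a higher number here means a weaker inhibitor, a lower number a stronger inhibitor:
compound 1, `c1ccc(OCc2cn(C(c3ccccc3)c3ccccc3)nn2)cc1`, gives 31300 nM
compound 2, `Cc1ccc(OCc2cn(C(c3ccccc3)c3ccccc3)nn2)cc1`, gives 26800 nM

For the measured compounds named here, compound 2 has the lower of the two numbers, but its only neighbour is compound 1, and the step of a 1.2-fold lower number from compound 1 to compound 2 (0.07 log units; within the scatter) stays within the scatter, so the two compounds cannot be told apart on these data. The next compound, compound 3, `c1ccc(-c2ccc(OCc3cn(C(c4ccccc4)c4ccccc4)nn3)cc2)cc1`, changes the same position again: phenyl in place of methyl on an aromatic carbon. Going by the values given here, the only measured step that bears on this change is the one from hydrogen to methyl at that aromatic carbon, a 1.2-fold lower number from compound 1 to compound 2 (0.07 log units; within the scatter), which produced no shift beyond the scatter. The swap of methyl for phenyl is a bigger structural change than the swap of hydrogen for methyl, and the two measurements give no guidance on whether continuing in this direction helps or hurts, so no direction can be read from them. The step of a 1.3-fold lower number from compound 2 to compound 3 (0.13 log units; within the scatter) is therefore expected to be small and of uncertain direction, with a wide range to allow for the untested larger change. For compound 3 in this assay the estimate is 20000 nM, with a range from 6000 nM to 60000 nM.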

Compound 3, half-maximal inhibitory concentration: 15500 nM
Estimate against measurement, compound 3: 1.3-fold (0.11 log units) above; low and high end bracket the measured number.
By their numbers in this assay, from the lowest: compounds 3, 2 and 1 (each within the scatter of the next, the first and the last beyond it).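

In this assay, replacing methyl with phenyl on this aromatic carbon gives a 1.7-fold lower number from compound 2 to compound 3 (0.24 log units; within the scatter) and so does not separate the two groups, even though phenyl is far larger than methyl. For the compounds shown here, the comparison with the unsubstituted compound says more: phenyl in place of hydrogen gives a 2.0-fold lower number from compound 1 to compound 3 (0.31 log units; beyond the scatter) and is the first step at this position to clear the scatter, although only modestly, so this place on the ring can carry a whole extra aromatic ring without any loss of inhibition in this assay. Nothing available explains this modest gain in terms of how the added ring acts.

On these data alone, the groups compared here at this place are hydrogen, methyl and phenyl, which contain only carbon and hydrogen, so it remains open how an amine, a carboxylic acid or a longer alkyl chain would read there. As far as these compounds go, it also remains open whether a further substituent on the added phenyl ring would extend this modest gain or lose it.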